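From 4-fluorophenyl to trifluoromethyl: notes on compound 4

This account rests on a few compounds, and the source may have more. Where it says the series, first, only, none or still open, it means among the compounds named here.

- compound 1 `CC1(COc2ccc(-c3ccc(F)cc3)cc2)Cn2cc([N+](=O)[O-])nc2O1`: > 64000 nM
- compound 2 `O=[N+]([O-])c1cnc2n1C[C@H](COc1ccc(OC(F)(F)F)cc1)O2`: > 64000 nM
- compound 3 `O=[N+]([O-])c1cnc2n1C[C@@H](COc1ccc(OC(F)(F)F)cc1)O2`: > 64000 nM

In an ADME assay on MRC5 cells (Homo sapiens) for cytotoxicity, read by fluorescence, with a stated time of 72 h (on this read-out lower numbers stand for stronger inhibition and higher numbers for weaker inhibition), compound 1 gives > 64000 nM, which is a limit of the assay and not a number. The record so far is the limit of > 64000 nM in this assay, at which 3 of the 3 values shown sit.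

Compound 4 `CC1(COc2ccc(C(F)(F)F)cc2)Cn2cc([N+](=O)[O-])nc2O1` carries trifluoromethyl in place of 4-fluorophenyl on an aromatic carbon, para to a large group: trifluoromethyl in place of 4-fluorophenyl on an aromatic carbon.

Among the measured compounds shown here, the only measured step is a step that the two limits leave unreadable from compound 2 to compound 3. It concerns (the fact that compounds 2 and 3 differ only in the configuration as drawn), so it gives no size for a change of this kind. For the measured compounds named here, no measured step covers the exchange of 4-fluorophenyl for trifluoromethyl.

The expectation therefore rests on compound 1 and its limit of > 64000 nM. No step beyond the scatter is expected in this assay, in either direction. The expected step is a number no higher from compound 1 to compound 4 (the limit leaves the size open). For compound 4 the estimate is 64000 nM, with the expected range running from 30000 nM to 100000 nM, and a report as a limit is the likeliest outcome.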

Compound 4, half-maximal inhibitory concentration: > 64000 nM
Compound 4: no number, only a limit; the forecaster's own chance of this, stated with the estimate: 85%; the middle value sits exactly at the limit.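

Compound 4, like compound 1, is reported only as a limit of the assay, so no step can be read between the two: the limit of > 64000 nM in this assay, at which 4 of the 4 values shown sit.

What the exchange of 4-fluorophenyl for trifluoromethyl does to the read-out in this assay stays open, since no compound shown gives a number there.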